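Swapping a Bromophenyl for a Pyridyl Ring

The source may hold more compounds than are shown below. What is called first, only, known or untested is meant among the compounds shown, and "the series" means these compounds.

Compound 2 `CC1=NC(C)=C(C(=O)O)C(c2cccc(Br)c2)/C1=C(\O)OC/C=C/c1ccccc1` gives 10 nM in a functional assay on thoracic aorta for inhibition of Voltage-gated L-type calcium channel (Rattus norvegicus) (on this read-out lower numbers stand for stronger inhibition and higher numbers for weaker inhibition), the lowest of the two numbers shown. Compound 1 `CC1=NC(C)=C(C(=O)O)C(c2cccc(C)c2)/C1=C(\O)OC/C=C/c1ccccc1` gives 76 nM, and the step of a 7.6-fold lower number from compound 1 to compound 2 (0.88 log units; beyond the scatter) lies beyond the scatter. Compound 3 `CC1=NC(C)=C(C(=O)O)C(c2cccnc2)/C1=C(\O)OC/C=C/c1ccccc1` differs from compound 2 in one place: pyridin-3-yl in place of 3-bromophenyl on a saturated ring carbon. Among the measured compounds shown here, no measured step tests this exact exchange; the only one swaps bromo for methyl. Without the bromine, compound 1 sat at 76 nM. Removing the bromine again is expected to cost potency, with a step of a 15-fold higher number from compound 2 to compound 3 (1.18 log units; beyond the scatter). Compound 3 is therefore estimated near 150 nM, within 30 nM to 800 nM.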

Compound 3, half-maximal inhibitory concentration: 190 nM
The estimate for compound 3 lay 1.3-fold (0.10 log units) below the measured number; low and high end bracket the measured number.
By their numbers in this assay, from the lowest: compound 2; then compound 1; then compound 3.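

Exchanging the whole ring at this saturated ring carbon gives a larger step (a 19-fold higher number from compound 2 to compound 3 (1.28 log units; beyond the scatter)) than the earlier swap of bromo for methyl. The step from the methyl compound is smaller (a 2.5-fold higher number from compound 1 to compound 3 (0.40 log units; beyond the scatter)), so pyridin-3-yl gives the weakest inhibition of the three groups shown here. Nothing available explains this order. The data leave open how much of the loss comes from the ring nitrogen and how much from removing the bromo or methyl group. A plain phenyl ring, or a pyridin-3-yl ring that keeps a bromo group, would help separate the two.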